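Three hydrazone limits and a fourth, untested analogue

The compounds below may be only part of what the source reports. "The series", "measured", "known", "first", "only" and "open" are said of these compounds alone.

Compound 1, `COc1cc(/C=N/Nc2nc(-c3ccc(C(F)(F)F)cc3)cs2)c(Br)c(Br)c1OC`: in an ADME assay on HUVEC cells (Homo sapiens) for inhibition, read by MTT assay, with a stated time of 48 h (a higher number here means a weaker inhibitor, a lower number a stronger inhibitor), compound 1 gives > 100000 nM, which is a limit of the assay and not a number.
Compound 2, `COc1cc(/C=N/Nc2nc(-c3ccccc3)cs2)c(Br)c(Br)c1OC`: in this assay compound 2 gives > 100000 nM, again a limit.
Compound 3, `COc1cc(/C=N/Nc2nc(-c3ccc(C(F)(F)F)cc3)cs2)cc(Br)c1OC`: in this assay compound 3 gives > 100000 nM, also a limit.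

Compound 1 and compound 2 differ by hydrogen in place of trifluoromethyl on an aromatic carbon, and the step that the two limits leave unreadable from compound 1 to compound 2 cannot be sized, because of the limit of > 100000 nM in this assay, at which 3 of the 3 values shown sit. Compound 1 and compound 3 differ by hydrogen in place of bromo on an aromatic carbon, and the step that the two limits leave unreadable from compound 1 to compound 3 is likewise hidden behind the same limit, so the two cores differ only in that bromo.

Compound 4, `COc1cc(/C=N/Nc2nc(-c3ccccc3)cs2)cc(Br)c1OC`, is not yet measured. It differs from compound 3 by hydrogen in place of trifluoromethyl on an aromatic carbon, the same change as from compound 1 to compound 2, at the same place. The known step that the two limits leave unreadable from compound 1 to compound 2 gives no readable size, so the expected step that the limit leaves unreadable from compound 3 to compound 4 rests only on the fact that every measured compound, including compound 3 with > 100000 nM, sits at the limit. Compound 4 is therefore expected to give about 150000 nM in this assay, most likely reported again as a limit, with an estimated range from 100000 nM to 300000 nM.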

Compound 4, half-maximal inhibitory concentration: > 100000 nM
Compound 4: a limit, no number; the forecaster's own chance of this, stated with the estimate: 90%; the middle value does not contradict the limit.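

Neither the step from compound 3 to compound 4 nor the step from compound 2 to compound 4 can be read, because the values at both ends of each step are limits, not numbers: the limit of > 100000 nM in this assay, at which 4 of the 4 values shown sit.

The compounds shown leave open whether swapping trifluoromethyl or bromo for hydrogen changes the result in this assay at all, and where the true value of each compound lies.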